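Removal of the methylcarbamoyl group from the series core

The source may report more compounds than this note shows. Statements on the series, on what has been measured and on what is new or still open speak of the compounds shown alone.

Three compounds of the series have numbers in an assay on isolated protein for inhibition of cathepsin S (Homo sapiens), read by fluorescence; a higher number here means a weaker inhibitor, a lower number a stronger inhibitor. Compound 1 `CN1CCC(Oc2nc(C#N)nc(NCC3CCC4(CC3)CC4)c2C(=O)NCc2ccccc2)CC1` gives 1 nM in this assay. Compound 2 `CN1CCC(COc2nc(C#N)nc(NCC3CCC4(CC3)CC4)c2C(=O)NCc2ccccc2)CC1` reaches only a limit of this assay, < 1 nM, so no number is known for it (the limit of < 1 nM in this assay, at which 1 of the 3 values shown sits). Compound 3 `CNC(=O)c1c(NCC2CCC3(CC2)CC3)nc(C#N)nc1OCCC1CCN(C)CC1` gives 2 nM in this assay, the highest of the two numbers shown, yet its gap to compound 1 lies within the scatter, so the two cannot be ranked.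

Among the measured compounds shown here, the single step measured, a number no higher from compound 1 to compound 2 (the limit leaves the size open), concerns only the chain on the ring oxygen and leaves its size open.

Compound 4 `CN1CCC(CCOc2cc(NCC3CCC4(CC3)CC4)nc(C#N)n2)CC1` differs from compound 3 in one place: hydrogen in place of methylcarbamoyl on an aromatic carbon. No measured step touches this group; the amide is kept in compound 1, compound 2 and compound 3, so the numbers shown give no guide to its removal. The change strips a hydrogen-bond donor and acceptor from the core, and the expectation is a clear weakening in this assay, a step of a 75-fold higher number from compound 3 to compound 4 (1.88 log units; beyond the scatter), well beyond the scatter, though with wide uncertainty. Compound 4 is therefore estimated at 150 nM in this assay, within a range of 15 nM to 1500 nM.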

Compound 4, half-maximal inhibitory concentration: 22 nM
Compound 4: middle estimate off by 6.8-fold (0.83 log units), on the high side; the measured number falls inside the stated range.
By their numbers in this assay, from the lowest: compounds 1 and 3 (each within the scatter of the next); then compound 4.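

In this assay the replacement of methylcarbamoyl by hydrogen, on the aromatic carbon ortho to a 2-(1-methylpiperidin-4-yl)ethoxy group and para to a cyano group, gives an 11-fold higher number from compound 3 to compound 4 (1.04 log units; beyond the scatter) as the only step shown at this position. Among the compounds shown here, compounds 1, 2 and 3 all keep an amide on this carbon, so only this pair shows that the number depends on the group there, while compound 4 still gives 22 nM without any amide on the shared core. This is one pair with one chain on the ring oxygen, and no line of measured data shown here bears on what lies behind the step.

The compounds shown leave open whether the step belongs to the amide hydrogen, the carbonyl or the whole methylcarbamoyl group, since that group leaves as one piece; a dimethylcarbamoyl group, a methoxy group or a small amine on this carbon would separate these parts. They also leave open whether the step has the same size with the chains of compound 1 or compound 2 on the ring oxygen.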